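Phenoxy in place of 3-methoxyphenyl: a step in the series

The source may report more compounds than this note shows. Statements on the series, on what has been measured and on what is new or still open speak of the compounds shown alone.

Of the compounds shown here, three sharing one core have been measured in a functional assay on CWR22R cells (Homo sapiens) for inhibition, read by sulforhodamine B assay, with a stated time of 72 h; a lower number here means a stronger inhibitor, a higher number a weaker inhibitor. Compound 1 (`COc1ccc(Cn2nnc(O)c2C(=O)Nc2cccc(-c3cccc(O)c3)c2)cc1`) gives 75700 nM, compound 2 (`COc1ccc(Cn2nnc(O)c2C(=O)Nc2cccc(-c3ccc(OC)cc3)c2)cc1`) gives 50100 nM and compound 3 (`COc1ccc(Cn2nnc(O)c2C(=O)Nc2cccc(-c3cccc(OC)c3)c2)cc1`) gives 59000 nM. Compound 3 therefore stands within the scatter of both other compounds, and the three values cannot be ranked.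

The next compound is compound 4 (`COc1ccc(Cn2nnc(O)c2C(=O)Nc2cccc(Oc3ccccc3)c2)cc1`), with phenoxy in place of 3-methoxyphenyl on an aromatic carbon, meta to a large group: phenoxy in place of 3-methoxyphenyl on an aromatic carbon.

Going by the values given here, three measured steps bear on this position: a 1.5-fold lower number from compound 1 to compound 2 (0.18 log units; within the scatter), a 1.3-fold lower number from compound 1 to compound 3 (0.11 log units; within the scatter) and a 1.2-fold higher number from compound 2 to compound 3 (0.07 log units; within the scatter). All three lie within the scatter, so the changes tested so far at this group have left this assay essentially flat. None of them, however, tests phenoxy, so they support the expectation only indirectly and the range has to stay wide. No step beyond the scatter is expected, and the estimated step is a 1.1-fold lower number from compound 3 to compound 4 (0.03 log units; within the scatter). For compound 4 the estimated value is 55000 nM, with an expected range of 25000 nM to 100000 nM.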

Compound 4, half-maximal inhibitory concentration: 65000 nM
Beside the measured number, compound 4's estimate is 1.2-fold (0.07 log units) below it; low and high end bracket the measured number.
By their numbers in this assay, from the lowest: compounds 2, 3, 4 and 1 (each within the scatter of the next).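

In this assay, going by these compounds alone, compound 4 gives 65000 nM, and phenoxy is the first group at this place that is not a substituted phenyl, yet the change from 3-methoxyphenyl to phenoxy on an aromatic carbon, meta to a large group, stays small (a 1.1-fold higher number from compound 3 to compound 4 (0.04 log units; within the scatter)). The same holds against the other two earlier groups, 4-methoxyphenyl (a 1.3-fold higher number from compound 2 to compound 4 (0.11 log units; within the scatter)) and 3-hydroxyphenyl (a 1.2-fold lower number from compound 1 to compound 4 (0.07 log units; within the scatter)), so all the comparisons among these four compounds lie within the scatter and the flat picture now extends beyond the substituted phenyl groups to phenoxy, with no order among the four. No measured information is available that would account for this flat response.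

Still open, on these data alone, is whether any group at this place can move this assay beyond the scatter, for example an amine, a carboxylic acid or a longer chain such as benzyloxy in place of phenoxy. As far as these compounds go, the rest of the shared core is the same in all four compounds, so what changes there would do to these high numbers also remains unknown.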